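The compounds below may be only part of what the source reports. "The series", "measured", "known", "first", "only" and "open" are said of these compounds alone.

In a functional assay on MDA-MB-231 cells (Homo sapiens) for cytotoxicity, read by MTT assay, with a stated time of 72 h (a higher number here means a weaker inhibitor, a lower number a stronger inhibitor), compound 1 `O=C(CN1CCN(c2nnc(Cc3ccncc3)c3ccccc23)CC1)Nc1cccc(Br)c1` gives 1.7 nM and compound 3 `O=C(CN1CCN(c2nnc(Cc3ccncc3)c3ccccc23)CC1)Nc1cccc(F)c1` gives 4.4 nM while compound 2 `O=C(CN1CCN(c2nnc(Cc3ccncc3)c3ccccc23)CC1)Nc1ccc(Br)cc1` gives 19 nM as the highest number of the three, beyond the scatter of both others. Compound 4 `O=C(CN1CCN(c2nnc(Cc3ccccc3)c3ccccc23)CC1)Nc1ccc(Br)cc1` differs from compound 2 by phenyl in place of pyridin-4-yl on a saturated chain carbon bound to an aromatic carbon in one place, with phenyl in place of pyridin-4-yl on a saturated chain carbon bound to an aromatic carbon. The measured steps, namely an 11-fold higher number from compound 1 to compound 2 (1.05 log units; beyond the scatter) and a 2.6-fold higher number from compound 1 to compound 3 (0.41 log units; beyond the scatter) and a 4.3-fold lower number from compound 2 to compound 3 (0.64 log units; beyond the scatter) all change the aromatic group on the amide-type nitrogen and leave pyridin-4-yl untouched. They show that numbers in this series can move with changes elsewhere in the molecule, but they give neither size nor direction for this exchange. No step beyond the scatter is therefore expected, in either direction, though the range stays wide. The estimate amounts to a 1.3-fold higher number from compound 2 to compound 4 (0.12 log units; within the scatter) as the expected step. For compound 4 the estimated value is 25 nM in this assay with an expected range from 6 nM to 100 nM in the same read-out.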

Compound 4, half-maximal inhibitory concentration: 12400 nM
Beside the measured number, compound 4's estimate is 500-fold (2.70 log units) below it, and the stated range ends below it.
By their numbers in this assay, from the lowest: compound 1; then compound 3; then compound 2; then compound 4.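

In this assay, within the data shown here, the exchange on a saturated chain carbon bound to an aromatic carbon gives a 650-fold higher number from compound 2 to compound 4 (2.81 log units; beyond the scatter), a larger step than any among the earlier compounds, all of which kept pyridin-4-yl and changed only the aromatic group on the amide-type nitrogen. This position therefore matters strongly for the read-out, even though the exchange keeps the count of heavy atoms and removes only the ring nitrogen with its one hydrogen-bond acceptor. No measurement shown accounts for the size of this step.

As far as these compounds go, the exchange can be read only with 4-bromophenyl on the amide-type nitrogen, so its size with the 3-bromophenyl of compound 1 or the 3-fluorophenyl of compound 3 stays open. Also open, from the compounds shown here alone, is how a pyrimidine ring or an aminophenyl group would compare at this position.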